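Trimming a Methoxy Group on the Ether Side Chain

This account rests on a few compounds, and the source may have more. Where it says the series, first, only, none or still open, it means among the compounds named here.

Compound 2 `CCC(COC)Oc1nc(C)nc2c1ncn2-c1ccc(C(C)C)cc1Br` carries a 1-(methoxymethyl)propoxy group on its core. Within the data shown here, in an in vitro assay on 293-EBNA cells for binding affinity to corticotropin-releasing factor receptor 1 (Homo sapiens) (a lower number here means a stronger inhibitor, a higher number a weaker inhibitor), compound 2 gives 9.7 nM, which is the higher of the two numbers measured so far. Its nearest neighbour is compound 1 `CCCC(CCC)Nc1nc(C)nc2c1ncn2-c1ccc(C(C)C)cc1Br`, which in this assay gives 3.6 nM. The step of a 2.7-fold higher number from compound 1 to compound 2 (0.43 log units; beyond the scatter) exchanged the whole (1-propylbutyl)amino group for the ether side chain, so it is a change of a different kind.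

Compound 3 `CCC(CC)Oc1nc(C)nc2c1ncn2-c1ccc(C(C)C)cc1Br` differs from compound 2 in one place: methyl in place of methoxy on a saturated chain carbon, two bonds along the chain from an oxygen on an aromatic ring. The side chain thus shrinks from 1-(methoxymethyl)propoxy to (pentan-3-yl)oxy.

Among the measured compounds shown here, none of the measured steps touches this methoxy group, so there is no direct precedent for its removal; the only step in hand concerns the attachment to the core. With nothing pointing either way, a step within the usual scatter is expected, and the change a 1.1-fold lower number from compound 2 to compound 3 (0.03 log units; within the scatter) is the estimate for this move. Compound 3 is therefore expected to give about 9 nM in this assay, with a range from 3 nM to 27 nM.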

Compound 3, inhibition constant: 3.5 nM
Compound 3: middle estimate off by 2.6-fold (0.41 log units), on the high side, within the range that was stated.
By their numbers in this assay, from the lowest: compounds 3 and 1 (each within the scatter of the next); then compound 2.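

In this assay, methyl in place of methoxy on this saturated chain carbon, two bonds along the chain from an oxygen on an aromatic ring, gives a 2.8-fold lower number from compound 2 to compound 3 (0.44 log units; beyond the scatter) and so shows that the far end of the ether side chain affects the number, even though the change is small and the step is modest. The comparison with the amine gives a 1.0-fold lower number from compound 1 to compound 3 (0.01 log units; within the scatter) for (pentan-3-yl)oxy in place of (1-propylbutyl)amino, so the gap seen earlier between compound 1 and compound 2 does not hold for every ether side chain, and an oxygen-linked chain on the shared core can match the nitrogen-linked one of compound 1. No measurement at hand says why this single swap moves the number.

The compounds shown leave open whether a hydroxy group or a longer chain such as propyl at the same carbon would give a number like that of compound 3 or like that of compound 2. They also leave open whether a methoxy group placed on the amine side chain of compound 1 would bring a step of similar size.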